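The source may report more compounds than this note shows. Statements on the series, on what has been measured and on what is new or still open speak of the compounds shown alone.

Measured compounds in a functional assay for antagonist activity at transient receptor potential cation channel subfamily V member 1 (Homo sapiens); on this read-out lower numbers stand for stronger inhibition and higher numbers for weaker inhibition:
compound 1 `COCc1nc(Nc2ccc(C(F)(F)F)cc2)c2ccc(-c3ncccc3C(F)(F)F)cc2n1`: 1.5 nM
compound 2 `O=P(O)(O)OCc1nc(Nc2ccc(C(F)(F)F)cc2)c2ccc(-c3ncccc3C(F)(F)F)cc2n1`: 46 nM

Compound 2 holds the highest number of the two measured; its nearest neighbour is compound 1, separated by a 31-fold higher number from compound 1 to compound 2 (1.49 log units; beyond the scatter). Compound 3 `OCCc1nc(Nc2ccc(C(F)(F)F)cc2)c2ccc(-c3ncccc3C(F)(F)F)cc2n1` is not yet measured. The change from compound 2 is a group of 2 heavy atoms (1 carbon, 1 oxygen; no ring) in place of a group of 5 heavy atoms (4 oxygen, 1 phosphorus; no ring), on a saturated chain carbon bound to an aromatic carbon. Going by the values given here, the one measured step that bears on it is the installation of the phosphate group, a 31-fold higher number from compound 1 to compound 2 (1.49 log units; beyond the scatter), which was large; the present change runs the other way, taking that group off again, so a large step back toward the number of compound 1 is expected. Among the compounds with values here, what remains in compound 3, a hydroxymethyl group on the saturated chain carbon, has no measured counterpart in this set, which widens the range. Compound 3 is expected to give 2.5 nM (range 0.8 nM to 10 nM), that is a step of an 18-fold lower number from compound 2 to compound 3 (1.26 log units; beyond the scatter) in the direction of stronger inhibition.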

Compound 3, half-maximal inhibitory concentration: 22 nM
Beside the measured number, compound 3's estimate is 8.8-fold (0.94 log units) below it; the measured number lies above the stated range.
By their numbers in this assay, from the lowest: compound 1; then compound 3; then compound 2.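

In this assay, taking off the phosphate group does not return the series to the number of compound 1: the change to hydroxymethyl gives only a 2.1-fold lower number from compound 2 to compound 3 (0.32 log units; beyond the scatter) and stays far from the starting point, with hydroxymethyl in place of methoxy giving a 15-fold higher number from compound 1 to compound 3 (1.17 log units; beyond the scatter) on the saturated chain carbon bound to an aromatic carbon. Most of the loss seen in a 31-fold higher number from compound 1 to compound 2 (1.49 log units; beyond the scatter) therefore also appears without phosphorus, so at this position it is not tied to the phosphate group alone. Nothing measured here accounts for either step.

Still open, from the compounds shown here alone, is whether the low number of compound 1 belongs to methoxy specifically or would survive other replacements. An ethoxy group, an amine, a carboxylic acid or a longer chain on the same carbon would each test this.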